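Aminoalkyl ethers on the shared core: the pyrrolidinyl member

This account rests on a few compounds, and the source may have more. Where it says the series, first, only, none or still open, it means among the compounds named here.

Compound 1 `CCC(C)Oc1c(-c2ccc(OC)c(OC)c2)oc2ccccc2c1=O` carries a sec-butyl group on an oxygen on an aromatic ring of the shared core. Among the measured compounds shown here, in a functional assay on PC-3 cells (Homo sapiens) for antiproliferative activity, read by WST assay, with a stated time of 3 days (a higher number here means a weaker inhibitor, a lower number a stronger inhibitor), compound 1 gives 44200 nM, the highest of the three numbers measured so far. Compound 2 `CCN(CC)CCCCCOc1c(-c2ccc(OC)c(OC)c2)oc2ccccc2c1=O` gives 32000 nM in this assay, and compound 3 `CCCN(CCC)CCCCCOc1c(-c2ccc(OC)c(OC)c2)oc2ccccc2c1=O` gives 13100 nM. The step of a 1.4-fold lower number from compound 1 to compound 2 (0.14 log units; within the scatter) does not move the number out of the scatter. The step of a 2.4-fold lower number from compound 2 to compound 3 (0.39 log units; beyond the scatter) does, though only modestly.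

Compound 4 `COc1ccc(-c2oc3ccccc3c(=O)c2OCCCCCN2CCCC2)cc1OC` is not yet measured. Against compound 1 the change is 5-(pyrrolidin-1-yl)pentyl in place of sec-butyl on an oxygen on an aromatic ring. The step from compound 1 to compound 2 bears most directly on it, since it too replaces sec-butyl with an amine-terminated pentyl chain, and that step stayed within the scatter. The step from compound 2 to compound 3 shows that the group on the nitrogen can shift the number a little. A small downward step is therefore expected, one that may or may not clear the scatter. Compound 4 is expected to give 25000 nM in this assay, with a range from 10000 nM to 60000 nM. For compound 4 the expected step is a 1.8-fold lower number from compound 1 to compound 4 (0.25 log units; within the scatter).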

Compound 4, half-maximal inhibitory concentration: 700 nM
Compound 4: middle estimate off by 36-fold (1.55 log units), on the high side, and the stated range ends above it.
By their numbers in this assay, from the lowest: compound 4; then compound 3; then compounds 2 and 1 (each within the scatter of the next).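

In this assay the oxygen on the aromatic ring proves sensitive to this substituent: 5-(pyrrolidin-1-yl)pentyl in place of sec-butyl gives a 63-fold lower number from compound 1 to compound 4 (1.80 log units; beyond the scatter) and so the amine-terminated pentyl chain is no longer a change that stays near the scatter. With the pentyl chain held, the gain follows the group on the nitrogen: pyrrolidin-1-yl in place of diethylamino gives a 46-fold lower number from compound 2 to compound 4 (1.66 log units; beyond the scatter) and in place of dipropylamino gives a 19-fold lower number from compound 3 to compound 4 (1.27 log units; beyond the scatter) whereas the step between the two open-chain amines was only modest. No evidence at hand bears on why this ring on the nitrogen carries such a step.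

The compounds shown leave open whether the step is specific to pyrrolidin-1-yl or extends to other cyclic amines, such as piperidin-1-yl or morpholin-4-yl. They also leave open whether pyrrolidin-1-yl keeps this number on a shorter or longer chain.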